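Swapping Fluorine for a Second Methoxy Group

The source may hold more compounds than are shown below. What is called first, only, known or untested is meant among the compounds shown, and "the series" means these compounds.

Of the compounds shown here, three have been tested in a functional assay on HOS-TE85 cells (Homo sapiens) for inhibition, read by CCK-8 assay, with a stated time of 72 h, tested at 1 uM; on this read-out lower numbers stand for less inhibition and higher numbers for more inhibition at the one concentration tested (going by the name of the read-out). Compound 1 `CCOc1ccccc1N1C(=O)C(C)SC1c1cccc(C(=O)NCCCCc2ccccc2)c1` gives 94%, compound 2 `COc1ccccc1N1C(=O)CSC1C(=O)NCCCCc1ccccc1` gives 0%, and compound 3 `COc1c(F)cccc1N1C(=O)CSC1c1cccc(C(=O)NCCCCc2ccccc2)c1` gives 12%. Compound 3 thus stands second highest of the three: its nearest neighbour is compound 2, lying lower by a margin beyond the usual scatter, while compound 1 lies far higher, also beyond the scatter.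

The next compound, compound 4 `COc1ccc(N2C(=O)CSC2c2cccc(C(=O)NCCCCc3ccccc3)c2)c(OC)c1`, differs from compound 3 in one place: 2,4-dimethoxyphenyl in place of 3-fluoro-2-methoxyphenyl on an amide-type nitrogen in a ring. The fluorine leaves and a further methoxy enters. Among the compounds with values here, no measured pair shows this change, so the size of the step is uncertain; a modest rise in this assay is expected, possibly no larger than the scatter. The step from compound 3 to compound 4 is therefore estimated at a number 10 percentage points higher from compound 3 to compound 4 (within the scatter). Compound 4 is expected to give 22%, within a range from 0% to 60%.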

Compound 4, a percentage reported as inhibition, at one concentration (the size of the read-out at that concentration, not a potency): 58%
Beside the measured number, compound 4's estimate is 36 percentage points below it, within the range that was stated.
By their numbers in this assay, from the lowest: compound 2; then compound 3; then compound 4; then compound 1.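

In this assay, within the data shown here, 2,4-dimethoxyphenyl in place of 3-fluoro-2-methoxyphenyl gives a number 46 percentage points higher from compound 3 to compound 4 (beyond the scatter) as the only change. This shows that the phenyl group on the amide-type nitrogen in a ring can by itself move the read-out well past the usual scatter, with the rest of the molecule held the same. No measurement shown accounts for the size of this step.

On these data alone, the fluorine leaves and a further methoxy enters in one change, so which of the two carries the rise stays open. Also open, as far as these compounds go, is how a dimethylamino group or a carboxylic acid on that phenyl would read.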